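This account rests on a few compounds, and the source may have more. Where it says the series, first, only, none or still open, it means among the compounds named here.

Measured so far in a functional assay on ECa-109 cells (Homo sapiens) for antiproliferative activity, read by MTT assay, with a stated time of 48 h; on this read-out higher numbers stand for weaker inhibition and lower numbers for stronger inhibition:
- compound 1 `Cn1cc(C2=C(c3nn(CCCN4CCCCC4)c4ncccc34)C(=O)N(c3cccc4ccccc34)C2=O)c2ccccc21` gives 1830 nM
- compound 2 `Cn1cc(C2=C(c3n[nH]c4ncccc34)C(=O)NC2=O)c2ccccc21` gives 46100 nM
- compound 3 `Cn1cc(C2=C(c3nn(CCCN4CCCCC4)c4ncccc34)C(=O)NC2=O)c2ccccc21` gives 42300 nM

Compound 2 sits at the top end of these numbers. The step to its nearest neighbour (a 1.1-fold lower number from compound 2 to compound 3 (0.04 log units; within the scatter)) lies within the scatter, while compound 1 has a far lower number.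

Compound 4 `Cn1cc(C2=C(c3n[nH]c4ncccc34)C(=O)N(c3cccc4ccccc34)C2=O)c2ccccc21` is still unmeasured. It differs from compound 2 by naphthalen-1-yl in place of hydrogen on an amide-type nitrogen in a ring.

The same exchange has been measured once, read in reverse, in the pair carrying 3-(piperidin-1-yl)propyl (a 23-fold higher number from compound 1 to compound 3 (1.36 log units; beyond the scatter)). That step is large and beyond the scatter. Adding the chain to compound 2 gave no step beyond the scatter (a 1.1-fold lower number from compound 2 to compound 3 (0.04 log units; within the scatter)), so the exchange may carry over to the pair without the chain. This rests on a single pair, however, and the data do not show whether the size of the step depends on the chain. A large step towards a lower number is therefore expected in this assay, with a wide margin. The estimate means a 15-fold lower number from compound 2 to compound 4 (1.19 log units; beyond the scatter) as the expected step. For compound 4 the expected value is 3000 nM within a range of 900 nM to 12000 nM as estimated here.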

Compound 4, half-maximal inhibitory concentration: > 100000 nM
Compound 4 gave a limit, no number; the forecaster's own chance of this, stated with the estimate: 5%; middle value at least 33-fold (1.52 log units) from the limit.
By their numbers in this assay, from the lowest: compound 1; then compounds 3 and 2 (each within the scatter of the next). At a limit, above all of these: compound 4.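

In this assay compound 4 gives > 100000 nM, which is a limit of the assay and not a number. Naphthalen-1-yl on the amide-type nitrogen does not act alike on the two cores: without the chain it gives an at least 2.1-fold higher number from compound 2 to compound 4 (0.33 log units; beyond the scatter), whereas its removal from the chain-bearing pair, the reverse reading, gives a 23-fold higher number from compound 1 to compound 3 (1.36 log units; beyond the scatter), so the direction of this change depends on what the aromatic nitrogen carries: the same change on two cores in this assay, a 23-fold higher number (1.36 log units; beyond the scatter) from compound 1 to compound 3 and an at least 2.1-fold lower number (0.33 log units; beyond the scatter) from compound 4 to compound 2, at least 50-fold (1.70 log units) apart, beyond the scatter of two such steps. The chain likewise matters only alongside naphthalen-1-yl, with a 1.1-fold lower number from compound 2 to compound 3 (0.04 log units; within the scatter) where the amide-type nitrogen carries hydrogen, against an at least 54-fold higher number from compound 1 to compound 4 (1.73 log units; beyond the scatter) for the loss of the chain where it carries naphthalen-1-yl, so among these four compounds only compound 1, which carries both groups, lies far below the others: the same change on two cores in this assay, a 1.1-fold lower number (0.04 log units; within the scatter) from compound 2 to compound 3 and an at least 54-fold lower number (1.73 log units; beyond the scatter) from compound 4 to compound 1, at least 50-fold (1.70 log units) apart, beyond the scatter of two such steps.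

Going by these compounds, how far compound 4 lies past its limit stays open, so the true size of its steps is unknown. On these data alone, it is also open whether the pairing with naphthalen-1-yl needs the piperidine end of the chain, or whether a dimethylamino group, a longer chain or a phenyl group on the amide-type nitrogen would serve as well.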